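From Cyclopropyl to tert-Butyl on the Shared Core

This account rests on a few compounds, and the source may have more. Where it says the series, first, only, none or still open, it means among the compounds named here.

Measured in an ADME assay on microsomes from liver (Mus musculus) for metabolic stability, read by LC-MS, using NADPH, with a stated time of 10 min, tested at 10 uM; on this read-out higher numbers stand for a longer-lived compound and lower numbers for a shorter-lived compound:
- compound 1 `N#Cc1ccnc(Oc2nn(C3CCC3)c3ncnc(N)c23)c1`: 0.4 h
- compound 2 `N#Cc1ccnc(Oc2nn(C3CC3)c3ncnc(N)c23)c1`: > 2.41 h (a limit)

The reading for compound 2 is only a limit, (the limit of > 2.41 h in this assay, at which 1 of the 2 values shown sits). Compound 3 `CC(C)(C)n1nc(Oc2cc(C#N)ccn2)c2c(N)ncnc21` carries tert-butyl in place of cyclopropyl on an aromatic nitrogen. One measured step changes the group at this place, an at least 6.0-fold higher number from compound 1 to compound 2 (0.77 log units; beyond the scatter), which is beyond the scatter. As far as these compounds go, that step shows how strongly this group can move the half-life, though tert-butyl itself is untested. A shorter half-life is therefore expected, with an at least 2.4-fold lower number from compound 2 to compound 3 (0.38 log units; beyond the scatter) as the expected change. For compound 3 the estimate is 1 h, with an expected range of 0.3 h to 3 h.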

Compound 3, half-life: 0.767 h
Compound 3: the middle estimate sits 1.3-fold (0.12 log units) above what was measured, and the stated range covers the measured number.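

In this assay, putting tert-butyl in place of cyclopropyl on the aromatic nitrogen gives an at least 3.1-fold lower number from compound 2 to compound 3 (0.49 log units; beyond the scatter). Cyclobutyl and tert-butyl, by contrast, cannot be told apart at this position: a 1.9-fold higher number from compound 1 to compound 3 (0.28 log units; within the scatter). Of these three groups, only cyclopropyl stands apart, and the reading for compound 2 is a limit: the limit of > 2.41 h in this assay, at which 1 of the 3 values shown sits.

As far as these compounds go, whether an open chain such as ethyl or isopropyl, or a larger ring such as cyclopentyl, would behave like cyclopropyl or like the other two groups remains open. From the compounds shown here alone, how long the half-life of compound 2 really is also stays unknown.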